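The compounds below may be only part of what the source reports. "The series", "measured", "known", "first", "only" and "open" are said of these compounds alone.

Measured so far:
compound 1 `O=C1NCc2c1c1c(c3[nH]c4ccccc4c23)CCc2cc(O)ccc2-1` — 9%
compound 2 `O=C1NCc2c1c1c(c3c2c2ccccc2n3CCO)CCc2cc(OCCOCc3ccccc3)ccc2-1` — 9%
compound 3 `COCCOc1ccc2c(c1)CCc1c-2c2c(c3c4ccccc4n(CCO)c13)CNC2=O` — 52%

All three numbers come from an assay on isolated protein for inhibition of mitogen-activated protein kinase kinase kinase 9 (Homo sapiens), tested at 1 uM; a lower number here means less inhibition, a higher number more inhibition at the concentration tested (going by the name of the read-out). Compound 2 stands level with compound 1 at the digits given, the two together forming the bottom of the three; the gap to compound 1 lies within the scatter, while compound 3 lies far above both. One single-place step is measured within the set: a number 43 percentage points higher from compound 2 to compound 3 (beyond the scatter), a large rise when the phenyl on the chain beyond the aromatic oxygen is dropped.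

Compound 4 `N#CCCCOc1ccc2c(c1)CCc1c-2c2c(c3c4ccccc4n(CCO)c13)CNC2=O` awaits measurement in this assay. It differs from compound 2 as follows: cyanomethyl in place of benzyloxy on a saturated chain carbon, two bonds along the chain from an oxygen on an aromatic ring. The measured step bears on this change only loosely: it also shortens the same chain on compound 2, and it was large, but there the benzyloxy lost only its phenyl, whereas here the whole benzyloxy leaves and a cyanomethyl enters. The direction of the measured step is therefore taken as a guide, its full size is not. For compound 4 the expected step is a number 21 percentage points higher from compound 2 to compound 4 (beyond the scatter), upward and beyond the scatter but short of the measured rise. Compound 4 is accordingly estimated at 30%, within a range from 10% to 55%.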

Compound 4, a percentage reported as inhibition, at one concentration (the size of the read-out at that concentration, not a potency): 58%
Estimate against measurement, compound 4: 28 percentage points below; measured number above the stated range.
By their numbers in this assay, from the lowest: compounds 1 and 2 (each within the scatter of the next); then compounds 3 and 4 (each within the scatter of the next).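

In this assay, cyanomethyl in place of benzyloxy on this saturated chain carbon, two bonds along the chain from an oxygen on an aromatic ring, gives a number 49 percentage points higher from compound 2 to compound 4 (beyond the scatter), so a large rise at this position does not depend on keeping the ether oxygen that remains in the chain of compound 3. Exchanging the two small chain ends, cyanomethyl in place of methoxy, gives a number 6 percentage points higher from compound 3 to compound 4 (within the scatter), so this read-out does not separate the nitrile end from the methoxy end, and among these three compounds only compound 2, with the benzyloxy group, sits low. Nothing measured here accounts for either step.

The compounds shown leave open whether the level of compound 3 and compound 4 holds with an amine or a carboxylic acid at the chain end, or with a chain longer than 3-cyanopropoxy. A pyridine ring at the chain end would test whether a low number goes with any ring there, a question that compound 2 alone cannot settle.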